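The source may report more compounds than this note shows. Statements on the series, on what has been measured and on what is new or still open speak of the compounds shown alone.

Measured in a functional assay on HT-29 cells (Homo sapiens) for inhibition, read by luminescence and CellTiter-Glo, with a stated time of 10 h; on this read-out higher numbers stand for an effect only at larger amounts of compound and lower numbers for an effect already at smaller amounts:
Compound 1 `CN1C(=S)[C@H](NC(=O)c2n[nH]c(Cc3ccccc3)n2)COc2ccccc21`: 22.6 nM; 76.3 nM (2 entries)
Compound 2 `O=C(N[C@@H]1COc2ccccc2NC1=S)c1n[nH]c(Cc2ccccc2)n1`: 8840 nM
Compound 3 `CCN1C(=S)[C@@H](NC(=O)c2n[nH]c(Cc3ccccc3)n2)COc2ccccc21`: 1510 nM

Among these, compound 2 stands at 8840 nM and compound 3 at 1510 nM, so compound 3 has the lower number of the two, a gap beyond the scatter, while compound 1 has lower numbers than either: the several entries of compound 1 in this assay, 22.6 nM; 76.3 nM (2 entries). Compound 4 `CCN1C(=S)[C@H](NC(=O)c2n[nH]c(Cc3ccccc3)n2)COc2ccccc21` is the next to be read against compound 3: the two compounds have the same atoms and bonds and differ only in configuration as drawn: 1 of 1 stereo elements differ; a stereocentre at a saturated ring carbon is drawn S in compound 3 and R in compound 4. Among the compounds with values here, no measured step isolates such a change. The expectation therefore rests on the values of compound 1 at 22.6 nM; 76.3 nM (2 entries), which show that much lower numbers occur among these compounds. A large move to a lower number in this assay, beyond the scatter, is expected. The estimated change is a 13-fold lower number from compound 3 to compound 4 (1.10 log units; beyond the scatter). For compound 4 the expected value is 120 nM, with an estimated range from 30 nM to 500 nM.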

Compound 4, half-maximal effective concentration: 6680 nM
Compound 4: middle estimate off by 56-fold (1.75 log units), on the low side, and the stated range ends below it.
By their numbers in this assay, from the lowest: compound 3; then compounds 4 and 2 (each within the scatter of the next).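

Drawing the stereocentre at the saturated ring carbon R rather than S gives a 4.4-fold higher number from compound 3 to compound 4 (0.65 log units; beyond the scatter), so configuration at this position shifts the number on its own, and the step can be read cleanly for one reason: the fact that compounds 3 and 4 differ only in the configuration as drawn. With ethyl in place of hydrogen on the amide-type nitrogen in a ring, the result is a 1.3-fold lower number from compound 2 to compound 4 (0.12 log units; within the scatter), so that replacement shows no effect beyond the scatter. The compounds shown leave open how a propyl chain or a methoxyethyl group on that nitrogen would read, and whether the configuration step keeps its size with another group there.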